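This account rests on a few compounds, and the source may have more. Where it says the series, first, only, none or still open, it means among the compounds named here.

Measured compounds:
- compound 1 `CC(C)(C)c1cc(/C=C/C(=O)NC2CCN(Cc3ccccc3)CC2)cc(C(C)(C)C)c1O` — 42500 nM
- compound 2 `CC(C)(C)c1cc(/C=C/C(=O)NCC2CCN(Cc3ccccc3)CC2)cc(C(C)(C)C)c1O` — 48400 nM
- compound 3 `CC(C)(C)c1cc(/C=C/C(=O)NCCC2CCN(Cc3ccccc3F)CC2)cc(C(C)(C)C)c1O` — 60200 nM

Of the compounds shown here, three sharing the same core have been tested in an assay on isolated protein for inhibition of Amine oxidase [flavin-containing] A (Homo sapiens), read by fluorescence, with stated times of 15 min and 20 min; a higher number here means a weaker inhibitor, a lower number a stronger inhibitor. Compound 1 `CC(C)(C)c1cc(/C=C/C(=O)NC2CCN(Cc3ccccc3)CC2)cc(C(C)(C)C)c1O` gives 42500 nM, compound 2 `CC(C)(C)c1cc(/C=C/C(=O)NCC2CCN(Cc3ccccc3)CC2)cc(C(C)(C)C)c1O` gives 48400 nM and compound 3 `CC(C)(C)c1cc(/C=C/C(=O)NCCC2CCN(Cc3ccccc3F)CC2)cc(C(C)(C)C)c1O` gives 60200 nM. Compound 3 has the highest number of the three, but the gap to compound 2 and the gap to compound 1 both lie within the usual scatter of repeated measurements, so no order among the three can be read from these values; all three are weak inhibitors in this assay.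

The next compound, compound 4 `CC(C)(C)c1cc(/C=C/C(=O)NCCC2CCN(Cc3ccc(C#N)cc3)CC2)cc(C(C)(C)C)c1O`, is not yet measured. It differs from compound 3 in one place: 4-cyanophenyl in place of 2-fluorophenyl on a saturated chain carbon bound to an amine nitrogen in a ring. For the measured compounds named here, no pair of measured compounds differing in one place is available, so no reference step exists for a change of this kind. Given that compounds 1, 2 and 3 lie so close together despite their differences, compound 4 is expected to stay in the same weak range, with a step of a 1.1-fold lower number from compound 3 to compound 4 (0.04 log units; within the scatter) that is expected to be no larger than the scatter. Compound 4 is therefore estimated at 55000 nM in this assay, with a range from 25000 nM to 120000 nM.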

Compound 4, half-maximal inhibitory concentration: 78200 nM
The estimate for compound 4 lay 1.4-fold (0.15 log units) below the measured number; low and high end bracket the measured number.
By their numbers in this assay, from the lowest: compounds 1, 2, 3 and 4 (each within the scatter of the next).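

For the compounds shown here, the exchange of 2-fluorophenyl for 4-cyanophenyl on a saturated chain carbon bound to an amine nitrogen in a ring gives the first comparison between compounds that differ in one place, and in this assay it amounts to a 1.3-fold higher number from compound 3 to compound 4 (0.11 log units; within the scatter). The two benzyl groups therefore cannot be told apart in this assay, even though the entering group carries a triple bond and a hydrogen-bond acceptor that the leaving group lacks, and the pair remains weak. No measurement is available that bears on why these two groups read alike.

This single exchange alters both the substituent and its place on the aromatic ring, so the compounds shown cannot separate the contribution of the fluorine from that of the nitrile, or either of these from the effect of where each group stands. From the compounds shown here alone, whether a plain benzyl, or a benzyl carrying an amine or a carboxylic acid, would move the number beyond the scatter remains open, as does whether any such group would lift this series out of its weak range.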